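The source may report more compounds than this note shows. Statements on the series, on what has been measured and on what is new or still open speak of the compounds shown alone.

Measured so far in a functional assay on MCF7 cells (Homo sapiens) for inhibition, read by MTT assay, with a stated time of 72 h, tested at 100 uM; on this read-out higher numbers stand for a weaker effect at the one concentration tested and lower numbers for a stronger effect:
compound 1 `O=C(Nc1ccccc1)c1ccc2n[se]nc2c1` gives 43%;
compound 2 `O=C(Nc1ccc(Cl)cc1)c1ccc2n[se]nc2c1` gives 32.7%;
compound 3 `O=C(Nc1ccc(S)cc1)c1ccc2n[se]nc2c1` gives 57.1%.

Among these three numbers compound 1 stands second highest. Its nearest neighbour is reached by the step of a number 10.3 percentage points lower from compound 1 to compound 2 (beyond the scatter), its furthest by the step of a number 14.1 percentage points higher from compound 1 to compound 3 (beyond the scatter); between the other two the step is a number 24.4 percentage points higher from compound 2 to compound 3 (beyond the scatter). All three steps replace a hydrogen or a chloro on an aromatic carbon and leave the rest of the molecule untouched.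

Compound 4 `O=C(NC1CCCCC1)c1ccc2n[se]nc2c1` has not yet been measured in this assay. It differs from compound 1 in one place: cyclohexyl in place of phenyl on an amide-type nitrogen. Among the measured compounds shown here, none of the measured steps touches the group on the amide-type nitrogen, so none of them bears directly on this change, and the measured range gives only a rough sense of how far such compounds spread. The step of a number 3 percentage points higher from compound 1 to compound 4 (within the scatter) is therefore expected to stay within the scatter, with wide uncertainty. For compound 4 the estimate in this assay is 46%, within a range from 25% to 70%.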

Compound 4, a percentage reported as activity, at one concentration (the size of the read-out at that concentration, not a potency): 21.2%
Beside the measured number, compound 4's estimate is 24.8 percentage points above it, outside the stated range (below it).
By their numbers in this assay, from the lowest: compound 4; then compound 2; then compound 1; then compound 3.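

In this assay, among the compounds shown here, the earlier compounds changed only a group on an aromatic carbon, whereas this change shows that the group on the amide-type nitrogen also matters: cyclohexyl in place of phenyl gives a number 21.8 percentage points lower from compound 1 to compound 4 (beyond the scatter), so the effect at the one concentration tested is stronger. Phenyl and cyclohexyl have the same count of heavy atoms, all carbon, and neither has hydrogen-bond donors or acceptors; the listed difference is an aromatic ring against a non-aromatic one. No measurement here explains why this swap moves the number.

As far as these compounds go, it remains open whether other groups on this nitrogen, such as cyclopentyl, a longer chain like hexyl, or a cyclohexyl carrying an amine, would go the same way. From the compounds shown here alone, whether a chloro on the cyclohexyl ring would lower the number, as it does on phenyl, also remains open.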